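This account rests on a few compounds, and the source may have more. Where it says the series, first, only, none or still open, it means among the compounds named here.

Measured compounds in a functional assay on the whole organism (blood, strain albino) with Mus musculus as the target, with stated times of 6 days and 4 h, at a dose of 0.4 mmol/kg by the oral route; on this read-out higher numbers stand for more inhibition at the one dose given (going by the name of the read-out) and lower numbers for less inhibition:
compound 1 `CCCNC(=S)NS(=O)(=O)c1ccc(-n2nc(C)cc2C)cc1` gives < 1%
compound 2 `C=CCNC(=S)NS(=O)(=O)c1ccc(-n2nc(C)cc2C)cc1` gives -1%
compound 3 `Cc1cc(C)n(-c2ccc(S(=O)(=O)NC(=S)NC3CCCCC3)cc2)n1` gives < 2%

Compound 3 stands at a limit of this assay, so its reading is a limit and not a number. Compound 1 likewise stands at a limit, and its reading too is a limit rather than a number. Compound 2 gives a number, and that number lies within the scatter of the other two readings as far as limits allow a comparison.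

Compound 4 `CCNC(=S)NS(=O)(=O)c1ccc(-n2nc(C)cc2C)cc1` is not yet measured; it differs from compound 3 in one place: ethyl in place of cyclohexyl on an amide-type nitrogen. Going by the values given here, the steps that bear on this change are the ones that bring the cyclohexyl onto the amide-type nitrogen: a step that the two limits leave unreadable from compound 1 to compound 3 and a step that the limit leaves unreadable from compound 2 to compound 3. Neither has a readable size: the readings of compound 3 and compound 1 are limits, as the limit of < 2% in this assay, at which 1 of the 3 values shown sits, and the limit of < 1% in this assay, at which 1 of the 3 values shown sits, show. Nothing in the three readings therefore points to a step beyond the scatter in either direction.

Ethyl in place of cyclohexyl is expected to leave compound 4 near the limits seen, and a step that the limit leaves unreadable from compound 3 to compound 4 is the step the estimate means. Compound 4 is accordingly estimated at 1%, within -5% to 7%, with a fair chance that only a limit is reported.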

Compound 4, a percentage reported as inhibition, in the whole organism at one dose (the size of the read-out at that dose, not a potency): 0%
Compound 4: the middle estimate sits 1 percentage points above what was measured; measured number inside the range.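

In this assay, going by these compounds alone, ethyl on the amide-type nitrogen gives the first step at this position that can be read as a number, and with a number 1 percentage points higher from compound 2 to compound 4 (within the scatter) ethyl and allyl cannot be told apart. Compound 1 and compound 3 carry limits, and the steps from them to compound 4 cannot be read. Replacing cyclohexyl with ethyl therefore brings no readable inhibition at this dose, and none of the four compounds shows a reading that stands clear of the others.

From the compounds shown here alone, it remains open whether any group on this nitrogen can raise the read-out at all, for instance a phenyl, a benzyl or a chain ending in a carboxylic acid. Also open, going by these compounds, is whether a carbonyl in place of the thiocarbonyl would change the reading on the shared core.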